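The source may report more compounds than this note shows. Statements on the series, on what has been measured and on what is new or still open speak of the compounds shown alone.

Measured so far:
- Compound 1 `Cc1ccc(C(O)(c2ccc(Cl)cc2)c2cccnc2)cc1`: 61000 nM
- Compound 2 `CS(=O)(=O)Nc1ccc(C(O)(c2ccc(Cl)cc2)c2cccnc2)cc1`: > 100000 nM (a limit)

Going by the values given here, in an ADME assay on L6 cells (Rattus norvegicus) for cytotoxicity, read by resazurin assay, with a stated time of 72 h (on this read-out higher numbers stand for weaker inhibition and lower numbers for stronger inhibition), compound 1 gives 61000 nM, the only true number so far. Compound 2 gives > 100000 nM, which is a limit of the assay and not a number. Among the compounds with values here, the one measured step, an at least 1.6-fold higher number from compound 1 to compound 2 (0.21 log units; that floor lies within the scatter), ends at the limit of > 100000 nM in this assay, at which 1 of the 2 values shown sits.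

Compound 3 `OC(c1ccc(Cl)cc1)(c1cccnc1)c1cccs1` is next: thiophen-2-yl in place of 4-methylphenyl on a saturated chain carbon bound to two aromatic carbons and an oxygen on a saturated carbon. Here thiophen-2-yl takes the place of 4-methylphenyl on a saturated chain carbon bound to two aromatic carbons and an oxygen on a saturated carbon. The step to compound 2 replaced only the methyl of that 4-methylphenyl, so it bears on this change only loosely, and its floor gives no sign of a large shift.

No shift beyond the scatter is expected in this assay, and the estimated step is a 1.1-fold higher number from compound 1 to compound 3 (0.06 log units; within the scatter). For compound 3 the estimated value is 70000 nM, with an expected range from 30000 nM to 100000 nM.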

Compound 3, half-maximal inhibitory concentration: 67700 nM
Estimate against measurement, compound 3: 1.0-fold (0.01 log units) above; measured number inside the range.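

In this assay, going by these compounds alone, the whole aromatic group on the saturated chain carbon bound to two aromatic carbons and an oxygen on a saturated carbon is exchanged for the first time, giving a 1.1-fold higher number from compound 1 to compound 3 (0.05 log units; within the scatter). The earlier step altered only the methyl of 4-methylphenyl, whereas this one shows that thiophen-2-yl, a five-membered aromatic ring with 1 hetero atom, can stand in place of the six-membered ring of carbon only without a shift beyond the scatter. Compound 2 remains a limit of the assay and not a number: the limit of > 100000 nM in this assay, at which 1 of the 3 values shown sits.

Going by these compounds, whether a non-aromatic group, such as an aminoalkyl or a longer alkyl chain, would be accepted at this carbon stays open. The compounds shown also keep the other two aromatic groups of the shared core fixed, so the part those groups play remains unknown.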